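This account rests on a few compounds, and the source may have more. Where it says the series, first, only, none or still open, it means among the compounds named here.

Of the compounds shown here, three built on one shared core have been measured so far. Compound 1 `Cn1c(=O)c(C(=O)Nc2ccc(F)cc2F)cc2cnc(Nc3ccc4[nH]ccc4c3)nc21` gives 5000 nM in a functional assay on DU-145 cells (Homo sapiens) for inhibition, read by trypan blue exclusion, with a stated time of 72 h; a higher number here means a weaker inhibitor, a lower number a stronger inhibitor. Compound 2 `COc1ccc(Nc2ncc3cc(S(=O)(=O)c4ccc(Cl)cc4)c(=O)n(C)c3n2)cc1` gives 30000 nM in this assay, and compound 3 `Cn1c(=O)c(S(=O)(=O)c2ccc(F)cc2F)cc2cnc(Nc3cnc4[nH]ccc4c3)nc21` gives 750 nM. Compound 1 therefore holds the second highest of the three numbers: compound 2 stands nearest to it with a higher number, compound 3 furthest with a lower number, and both gaps lie beyond the scatter. No two of these three compounds differ in one place only, so no single step can be read from them.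

Compound 4 `Cn1c(=O)c(S(=O)(=O)c2ccc(Br)cc2)cc2cnc(Nc3ccc4[nH]ccc4c3)nc21` has not yet been measured. It differs from compound 1 in one place: (4-bromophenyl)sulfonyl in place of (2,4-difluorophenyl)carbamoyl on an aromatic carbon. The group that enters sits on an aromatic carbon of a six-membered aromatic ring with one nitrogen, part of a fused system of two rings, ortho to a group of one heavy atom and para to a fused ring. Compound 3 carries a sulfonyl at that place and shows the lowest number of the three, while compound 2 also carries a sulfonyl and shows the highest, so the three values do not settle the direction on their own. The step from compound 1 to compound 4 is expected to be modest and toward a lower number, a 2.5-fold lower number from compound 1 to compound 4 (0.40 log units; beyond the scatter). Compound 4 is expected to give about 2000 nM in this assay, within a range from 500 nM to 8000 nM.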

Compound 4, half-maximal inhibitory concentration: 5000 nM
Compound 4: the middle estimate sits 2.5-fold (0.40 log units) below what was measured, and the stated range covers the measured number.
By their numbers in this assay, from the lowest: compound 3; then compounds 1 and 4 (each within the scatter of the next); then compound 2.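

In this assay, among these compounds, placing (4-bromophenyl)sulfonyl on this aromatic carbon in place of (2,4-difluorophenyl)carbamoyl gives no change at the digits printed from compound 1 to compound 4 (within the scatter), and this is the first reading at this position in which nothing else in the molecule differs. The carbon thus carries either group with no difference that can be read in this assay, although the group that leaves has a hydrogen-bond donor and the group that enters has none, and the two differ in their halogens as well as in the link to the aromatic ring.

Going by these compounds, both the link and the halogens differ in this single step, so it remains open whether each is without effect alone or whether two separate effects offset each other, and (2,4-difluorophenyl)sulfonyl on the core of compound 1 would bear on that question. On these data alone, it is also open how this position responds to groups of another kind, such as a carboxylic acid, a simple amine or a longer alkyl chain in place of the aromatic ring. No measurement offered here gives any explanation for this result.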